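A few compounds are considered here, and "the series" means these few. Any claim that something is new, unique, unknown or untested is made for them only; others in the source may bear on it.

Measured so far in a functional assay on A549 cells (Homo sapiens) for antiproliferative activity, read by MTT assay, with a stated time of 48 h; a lower number here means a stronger inhibitor, a higher number a weaker inhibitor:
- compound 1 `CC(C)=CCC[C@]1(C)/C=C/[C@@H](OC(=O)C=C(C)C)[C@](C)(O)/C=C/C(=O)/C(CN(C(C)C)C(C)C)=C\C1`: 650 nM
- compound 2 `CC(C)=CCC[C@]1(C)/C=C/[C@@H](OC(=O)C=C(C)C)[C@](C)(O)/C=C/C(=O)/C(C[Si](c2ccccc2)(c2ccccc2)C(C)(C)C)=C\C1`: 13000 nM
- compound 3 `CC(C)=CCC[C@](C)(/C=C/[C@@H](OC(=O)C=C(C)C)[C@](C)(O)/C=C/C(=O)/C=C/N(C)C)CC=O`: 11200 nM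

Compound 1 holds the lowest number of the three in this assay. Compound 3 stands nearest to it and compound 2 furthest, and both gaps lie beyond the usual scatter, so compound 1 is the strongest inhibitor of the measured set. Among the measured compounds shown here, no pair of measured compounds differs in a single place, so no step size can be read from the measured set itself; compound 2 and compound 3 each change the core of compound 1 in their own way, and their numbers say only that both changes gave weaker inhibitors.

Compound 4 `CC(C)=CCC[C@]1(C)/C=C/[C@@H](OC(=O)C=C(C)C)[C@](C)(O)/C=C/C(=O)/C(C(=O)N2CCCC2)=C\C1` has not been measured. Against compound 1 it differs in one place:

(pyrrolidin-1-yl)carbonyl in place of (diisopropylamino)methyl on a double-bonded ring carbon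

For the measured compounds named here, no measured compound carries this group, so the step is untested. The step of a 3.8-fold higher number from compound 1 to compound 4 (0.59 log units; beyond the scatter) is expected to be modest and in the direction of a weaker inhibitor, likely beyond the scatter. Compound 4 is estimated at 2500 nM, within a range of 700 nM to 10000 nM.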

Compound 4, half-maximal inhibitory concentration: 13000 nM
Compound 4: middle estimate off by 5.2-fold (0.72 log units), on the low side, and the stated range ends below it.
By their numbers in this assay, from the lowest: compound 1; then compounds 3, 2 and 4 (each within the scatter of the next).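

In this assay, among the compounds shown here, the single change at this double-bonded ring carbon gives a 20-fold higher number from compound 1 to compound 4 (1.30 log units; beyond the scatter), so this position does not tolerate every replacement of the (diisopropylamino)methyl group, and the step is large. Compound 2, with a silyl-bearing group at the same ring carbon, gives 13000 nM and compound 4 gives 13000 nM, so two quite different groups here print the same number, while compound 1 remains alone at the low end. No measurement on hand bears on the cause of this loss.

On these data alone, the step swaps the linking methylene for a carbonyl and the diisopropylamino part for a pyrrolidine ring at once, so the two changes cannot be told apart. (Pyrrolidin-1-yl)methyl and (diisopropylamino)carbonyl at this ring carbon would separate them, and a primary amine or a carboxylic acid there remains open.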